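Methoxy removal on the styryl end of the dienone series

The compounds below may be only part of what the source reports. "The series", "measured", "known", "first", "only" and "open" are said of these compounds alone.

Three compounds of the series are measured in a functional assay on COLO 205 cells (Homo sapiens) for inhibition, read by sulforhodamine B assay, with a stated time of 48 h, tested at 50 uM; a higher number here means more inhibition of growth at the concentration tested, a lower number less inhibition of growth. Compound 2 `COc1ccccc1/C=C/C(=O)/C=C/c1ccc(OCc2cn(CCCCOc3cc(=O)oc4ccccc34)nn2)c(OC)c1` gives 47%. Compound 1 `COc1cc(/C=C/C(=O)/C=C/c2ccccc2)ccc1OCc1cn(CCCCOc2cc(=O)oc3ccccc23)nn1` differs from compound 2 by hydrogen in place of methoxy on an aromatic carbon, and compound 1 gives 31%; the step is a number 16 percentage points lower from compound 2 to compound 1 (beyond the scatter). Compound 3 `COc1ccccc1/C=C/C(=O)/C=C/c1ccc(OCc2cn(CCCCCOc3cc(=O)oc4ccccc34)nn2)c(OC)c1` gives 30%; compound 3 and compound 1 sit within the scatter of each other, while the difference between the core of compound 2 and the core of compound 3 is not broken down here.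

Compound 4 `COc1cc(/C=C/C(=O)/C=C/c2ccccc2)ccc1OCc1cn(CCCCCOc2cc(=O)oc3ccccc23)nn1` is not yet measured. Going by the values given here, it differs from compound 3 by hydrogen in place of methoxy on an aromatic carbon, which is the same change, at the same place, as the one that separates compound 1 from compound 2. That single measured instance is the only support for the expectation, and one pair leaves the size of the step uncertain.

Among the compounds with values here, the expected step for compound 4 is a number 15 percentage points lower from compound 3 to compound 4 (beyond the scatter), because the only measured instance of this change is a number 16 percentage points lower from compound 2 to compound 1 (beyond the scatter). Compound 4 is therefore expected to give 15% in this assay. The estimated range for compound 4 runs from 3% to 28%, with the lower end reflecting that compound 3 already starts at the low end of the three measured numbers.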

Compound 4, percent growth inhibition at one concentration: 22%
The estimate for compound 4 lay 7 percentage points below the measured number, within the range that was stated.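

Hydrogen in place of methoxy was carried to a second core in this assay, and the new step reads a number 8 percentage points lower from compound 3 to compound 4 (within the scatter). Set beside the earlier instance of the same change, the two steps cannot be told apart, so these two pairs give no sign that the size of the step depends on the core: the same change on two cores in this assay, a number 16 percentage points lower (beyond the scatter) from compound 2 to compound 1 and a number 8 percentage points lower (within the scatter) from compound 3 to compound 4, 8 percentage points apart, within the scatter of two such steps This does not fix a single size for the step, since the new step lies within the scatter on its own and so does not establish by itself that compound 3 and compound 4 differ, and two cores are too few to show how the change behaves across the wider series.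

The compounds shown leave open whether the methoxy on this ring can give way to anything other than hydrogen, such as a hydroxyl, a fluorine or an amine, and whether the same step holds with a longer chain joining the two ends of the molecule. Going by these compounds, each number is also a reading at a single concentration on one cell line, so the behaviour at other concentrations and in other cell lines remains open.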